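The source may hold more compounds than are shown below. What is called first, only, known or untested is meant among the compounds shown, and "the series" means these compounds.

Compound 1 `CC(C#CCn1ccnc1)N1CCCC1=O` gives > 100 mg/kg in a functional assay on the whole organism for agonist activity, with Mus musculus as the target (on this read-out higher numbers stand for an effect only at larger amounts of compound and lower numbers for an effect already at smaller amounts), a limit of the assay rather than a number. Compound 2 `CC(C#CCN(C)C)N1CCCC1=O` gives 100 mg/kg in this assay. Compound 3 `CC1CCC(=O)N1CC#CCn1ccnc1` gives > 100 mg/kg in this assay, again a limit rather than a number.

The step of a number no higher from compound 1 to compound 2 (the limit leaves the size open) comes with the change (dimethylamino in place of 1H-imidazol-1-yl on a saturated chain carbon bound to a triple-bonded carbon). Its size cannot be read, since compound 1 sits at the limit of > 100 mg/kg in this assay, at which 2 of the 3 values shown sit. The core of compound 1 and the core of compound 3 hold the same atoms joined differently; how they differ is not broken down here.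

Compound 4 `CC1CCC(=O)N1CC#CCN(C)C` has not yet been measured in this assay. It arises from compound 3 by dimethylamino in place of 1H-imidazol-1-yl on a saturated chain carbon bound to a triple-bonded carbon, the same change, at the same place, as from compound 1 to compound 2. For compound 4 the step of a number no higher from compound 3 to compound 4 (the limit leaves the size open) is expected, resting on the step of a number no higher from compound 1 to compound 2 (the limit leaves the size open) and on compound 2 giving 100 mg/kg, while compound 3 sits at the limit of > 100 mg/kg in this assay, at which 2 of the 3 values shown sit. The estimate for compound 4 in this assay is 100 mg/kg, expected to lie between 40 mg/kg and 300 mg/kg.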

Compound 4, dose for half-maximal effect: 1.7 mg/kg
Beside the measured number, compound 4's estimate is 59-fold (1.77 log units) above it; the measured number lies below the stated range.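

In this assay, dimethylamino in place of 1H-imidazol-1-yl gives an at least 58-fold lower number from compound 3 to compound 4 (1.76 log units; beyond the scatter), a large move towards an effect at much smaller doses. Compound 1 gives > 100 mg/kg, a limit of the assay and not a number, so the size of the step that starts from it cannot be read. The change thus lowers the number on the core of compound 3 and does not raise it on the core of compound 1, which shows a shared direction but not that the size carries over from one core to the other: the same change on two cores in this assay, a number no higher (the limit leaves the size open) from compound 1 to compound 2 and an at least 58-fold lower number (1.76 log units; beyond the scatter) from compound 3 to compound 4; the limit leaves it open whether they differ

Going by these compounds alone, with only two cores and two groups at this place, this comparison rests on just one pair of compounds per core, so it cannot be stretched into a general rule. As far as these compounds go, it stays open how another amine, such as diethylamino, would behave on either core, and whether a longer chain carrying dimethylamino would hold the effect that compound 4 shows at 1.7 mg/kg.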